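The compounds below may be only part of what the source reports. "The series", "measured", "known", "first", "only" and "open" are said of these compounds alone.

Compound 2 `CC(C)CS(=O)(=O)N[C@@H](CNC(=O)c1ccc2c(c1)C(=O)N(CCC1CCNCC1)C2)C(=O)O` is measured in a functional assay for inhibition, with Homo sapiens as the target (a higher number here means a weaker inhibitor, a lower number a stronger inhibitor), at 9 nM, and compound 1 `CS(=O)(=O)N[C@@H](CNC(=O)c1ccc2c(c1)C(=O)N(CCC1CCNCC1)C2)C(=O)O` gives 14 nM in this assay; the step of a 1.6-fold lower number from compound 1 to compound 2 (0.19 log units; within the scatter) keeps the two within the scatter, so compound 2 stands alongside compound 1 rather than apart from it. Compound 3 `CCCCNS(=O)(=O)N[C@@H](CNC(=O)c1ccc2c(c1)C(=O)N(CCC1CCNCC1)C2)C(=O)O` differs from compound 2 by butylamino in place of isobutyl on a sulfonyl sulfur. For the measured compounds named here, the one measured step also touched the group on the sulfonyl sulfur and stayed small, so the change to compound 3 is expected to give a 1.3-fold higher number from compound 2 to compound 3 (0.12 log units; within the scatter), with no clear direction. Compound 3 is therefore estimated at 12 nM, in the range 5 nM to 30 nM.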

Compound 3, half-maximal inhibitory concentration: 19 nM
Compound 3: the middle estimate sits 1.6-fold (0.20 log units) below what was measured; the measured number falls inside the stated range.
By their numbers in this assay, from the lowest: compounds 2, 1 and 3 (each within the scatter of the next, the first and the last beyond it).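

Butylamino on the sulfonyl sulfur adds a nitrogen with a hydrogen-bond donor, and it gives the first step at this position to pass the scatter, if only modestly (a 2.1-fold higher number from compound 2 to compound 3 (0.32 log units; beyond the scatter)). Against methyl the same group gives a step that stays within the scatter (a 1.4-fold higher number from compound 1 to compound 3 (0.13 log units; within the scatter)), so chain size and the added nitrogen are not separated by these compounds. Nothing available explains the step from isobutyl to butylamino. A plain butyl chain on the sulfur would separate the chain shape from the nitrogen, and a phenyl ring would test a much different group.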